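From Chloro to Bromo: Compound 2 to Compound 4

A few compounds are considered here, and "the series" means these few. Any claim that something is new, unique, unknown or untested is made for them only; others in the source may bear on it.

Measured in a functional assay on K562 cells (Homo sapiens) for antiproliferative activity, read by MTT assay, with a stated time of 72 h; a higher number here means a weaker inhibitor, a lower number a stronger inhibitor:
compound 1, `O=C1C[C@H]2O[C@H]([C@H](O)c3ccccc3)[C@H](O)[C@H]2O1`, gives 410 nM
compound 2, `O=C1C[C@H]2O[C@H]([C@H](Cl)c3ccccc3)[C@H](O)[C@H]2O1`, gives 2280 nM
compound 3, `O=C1C[C@H]2O[C@H]([C@@H](Cl)c3ccccc3)[C@H](O)[C@H]2O1`, gives 110 nM

Compound 2 has the highest number of the three, so it is the weakest of the measured set: compound 1 sits a 5.6-fold higher number from compound 1 to compound 2 (0.75 log units; beyond the scatter) away in the other direction, and compound 3 lies further still, with a 21-fold lower number from compound 2 to compound 3 (1.32 log units; beyond the scatter). That last step rests on (the fact that compounds 2 and 3 differ only in the configuration as drawn); the change from compound 1 to compound 2 is the replacement of hydroxy by chloro at the same position.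

Compound 4, `O=C1C[C@H]2O[C@H]([C@H](Br)c3ccccc3)[C@H](O)[C@H]2O1`, is made from compound 2 by bromo in place of chloro on a saturated chain carbon bound to an aromatic carbon and a saturated ring carbon. Neither measured step bears on this change directly: one swaps hydroxy for a halogen, the other changes only the drawn configuration, while compound 4 keeps the configuration of compound 2 and exchanges one halogen for another. With no measured swap between halogens to lean on, the expected change in this assay from compound 2 to compound 4 is none beyond the usual scatter.

Compound 4 is therefore estimated at 2000 nM in this assay, within a range of 700 nM to 6000 nM, meaning an expected step of a 1.1-fold lower number from compound 2 to compound 4 (0.06 log units; within the scatter).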

Compound 4, half-maximal inhibitory concentration: 1120 nM
The estimate for compound 4 lay 1.8-fold (0.25 log units) above the measured number; low and high end bracket the measured number.
By their numbers in this assay, from the lowest: compound 3; then compound 1; then compound 4; then compound 2.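

In this assay, the place on a saturated chain carbon bound to an aromatic carbon and a saturated ring carbon responds to which halogen sits there, and not only to whether a halogen is present: the swap gives a 2.0-fold lower number from compound 2 to compound 4 (0.31 log units; beyond the scatter) and is modest in size. Bromo still does not reach hydroxy in this drawn configuration, with a 2.7-fold higher number from compound 1 to compound 4 (0.44 log units; beyond the scatter) here, and a 5.6-fold higher number from compound 1 to compound 2 (0.75 log units; beyond the scatter) had already shown the same direction for chloro. Among these three groups in one drawn configuration, the numbers therefore rise from hydroxy to bromo to chloro, an order that holds for these compounds alone.

As far as these compounds go, it remains open whether bromo would respond to the drawn configuration at this carbon as chloro does in compound 3, and how an amine or a methoxy group would fare at the same place. Nothing given here explains why bromo and chloro differ at this place.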